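Hydrogen in Place of Methyl on Selenium: An Expectation

The compounds below may be only part of what the source reports. "The series", "measured", "known", "first", "only" and "open" are said of these compounds alone.

Compound 1, `CCCCC[Se]c1nc(N)c2ccccc2n1`: > 100000 nM
Compound 2, `C[Se]c1nc(N)c2ccccc2n1`: > 100000 nM
Compound 3, `C[Se]c1nc([Se]C)c2cccnc2n1`: "not determined" (no result reported)

Three compounds have been examined in a functional assay on CCRF-CEM cells (Homo sapiens) for cytotoxicity, read by MTT assay, with a stated time of 72 h; on this read-out higher numbers stand for lower toxicity in this test and lower numbers for higher toxicity in this test. Compound 1 reaches only a limit of the assay there, reported as > 100000 nM. Compound 2 likewise gives only a limit, > 100000 nM. For compound 3 no result is reported, the entry reading "not determined" (no result reported). Going by the values given here, the single step between measured compounds, a step that the two limits leave unreadable from compound 1 to compound 2, cannot be read in size, since both of its ends sit at the limit of > 100000 nM in this assay, at which 2 of the 3 values shown sit. Compound 2 therefore stands only at a limit, with one further value also a limit and one further entry without a number.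

The unmeasured compound 4, `Nc1nc([SeH])nc2ccccc12`, differs from compound 2 in one place: hydrogen in place of methyl on a selenium. No measured step with a readable size bears on this change; the only step shown, a step that the two limits leave unreadable from compound 1 to compound 2, also shrinks the group carried on the selenium side of the core but is unreadable. With nothing to indicate a shift, compound 4 is expected to give 100000 nM, with a range from 30000 nM to 300000 nM, and most probably again only a limit. The expected step of a number no higher from compound 2 to compound 4 (the limit leaves the size open) is estimated to lie within the scatter.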

Compound 4, concentration lethal to 50% of the cells: 79100 nM
Estimate against measurement, compound 4: 1.3-fold (0.10 log units) above; low and high end bracket the measured number.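

In this assay compound 4 is the first of these compounds to give a number rather than a limit, 79100 nM, so a selenium carrying hydrogen gives a readable value where the same place carrying methyl or pentyl did not. Hydrogen in place of methyl gives an at least 1.2-fold lower number from compound 2 to compound 4 (0.10 log units; that floor lies within the scatter), and hydrogen in place of pentyl gives an at least 1.2-fold lower number from compound 1 to compound 4 (0.10 log units; that floor lies within the scatter); each of these is only a floor, so neither shows a change beyond the usual scatter, and the true size of each step remains unknown. Each floor rests on a limit and not on a number at its other end: the limit of > 100000 nM in this assay, at which 2 of the 4 values shown sit.

From the compounds shown here alone, how far compound 1 and compound 2 really lie from compound 4 stays open, and with it whether the change at this selenium matters at all in this assay. Also open, going by these compounds, is whether a chain on the selenium ending in an amine or a carboxylic acid, or a sulfur atom in place of the selenium, would give a number there.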